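Inverting One Ring Stereocentre in Compound 1

This account rests on a few compounds, and the source may have more. Where it says the series, first, only, none or still open, it means among the compounds named here.

Measured compounds:
compound 1, `CC[C@@H]1CN(c2ccc(C(=O)Nc3cn4cc(C)nc4cn3)c(F)c2)CCN1`: 19000 ng.h/mL
compound 2, `Cc1cn2cc(NC(=O)c3ccc(N4CCNC(C)C4)cc3F)nc2c(C)n1`: 7900 ng.h/mL

In an ADME assay on the whole organism (strain FVB) for pharmacokinetics, with Mus musculus as the target, read by LC-MS, with a stated time of 10 days, at a dose of 10 mg/kg by the oral route (a higher number here means more compound in the circulation at the dose given, a lower number less compound in the circulation), compound 1 gives 19000 ng.h/mL, the higher of the two numbers; compound 2 gives 7900 ng.h/mL, a gap beyond the scatter. Compound 3, `CC[C@H]1CN(c2ccc(C(=O)Nc3cn4cc(C)nc4cn3)c(F)c2)CCN1`, is drawn with the opposite configuration: the two compounds have the same atoms and bonds and differ only in configuration as drawn: 1 of 1 stereo elements differ; a stereocentre at a saturated ring carbon is drawn R in compound 1 and S in compound 3. Going by the values given here, no measured pair shows this change, so the size of the step in this assay cannot be read from the numbers; a modest fall, near the edge of the scatter, is expected. For compound 3 the estimate is 12000 ng.h/mL, within 4000 ng.h/mL to 35000 ng.h/mL. The expected step is a 1.6-fold lower number from compound 1 to compound 3 (0.20 log units; within the scatter).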

Compound 3, area under the concentration-time curve: 27100 ng.h/mL
The estimate for compound 3 lay 2.3-fold (0.35 log units) below the measured number, and the stated range covers the measured number.
By their numbers in this assay, from the lowest: compound 2; then compounds 1 and 3 (each within the scatter of the next).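

In this assay, going by these compounds alone, inverting the stereocentre at the saturated ring carbon gives a 1.4-fold higher number from compound 1 to compound 3 (0.15 log units; within the scatter), the first direct reading of this change. Either drawn configuration at this position therefore serves in this assay, with no separation between the two forms beyond the scatter. The comparison rests on a single point: the fact that compounds 1 and 3 differ only in the configuration as drawn.

As far as these compounds go, whether this indifference to configuration would hold with a longer chain or a hydroxyl group on that ring carbon stays open. So does whether it extends to other doses or routes.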